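The compounds below may be only part of what the source reports. "The series", "measured", "known", "first", "only" and "open" are said of these compounds alone.

Compound 1 `O=C(/C=C/c1ccc(C(F)(F)F)cc1)c1ccc(O)cc1O` offers no number to start from in a functional assay on A375-C5 cells (Homo sapiens) for inhibition, read by sulforhodamine B assay, with a stated time of 48 h (on this read-out higher numbers stand for weaker inhibition of growth and lower numbers for stronger inhibition of growth), where its entry is "not determined" (no result reported) and no result was reported. The only measured figure comes from compound 2 `O=C(/C=C/c1ccc(OCc2ccccc2)cc1)c1ccc(O)cc1O`, which gives 9000 nM in this assay as the sole anchor. Compound 3 `Cc1c(O)ccc(C(=O)/C=C/c2ccc(C(F)(F)F)cc2)c1O` differs from compound 1 by methyl in place of hydrogen on an aromatic carbon in one place, methyl in place of hydrogen on an aromatic carbon. Within the data shown here, no measured step shows what this change does, so no shift beyond the scatter is expected in this assay in either direction. Compound 3 is therefore estimated at 8000 nM with an expected span between 2500 nM and 25000 nM around that anchor.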

Compound 3, concentration for 50% growth inhibition: 24700 nM
Compound 3: the middle estimate sits 3.1-fold (0.49 log units) below what was measured; the range from low to high includes it.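

Among these compounds, with no number for compound 1, the pair of compound 1 and compound 3 yields no step. What the methyl in place of hydrogen does in this assay stays open, and no evidence shown bears on the result for compound 3.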